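From 4-isopropylphenyl to 2-isopropylphenyl

The source may report more compounds than this note shows. Statements on the series, on what has been measured and on what is new or still open speak of the compounds shown alone.

For the measured compounds named here, in a functional assay on MCF7 cells (Homo sapiens) for inhibition, read by CCK-8 assay, with a stated time of 48 h (on this read-out higher numbers stand for weaker inhibition of growth and lower numbers for stronger inhibition of growth), compound 2 `CC(C)c1ccc(Nc2nc(Nc3ccc(N4CCN(C)CC4)cn3)ncc2Cl)cc1` holds the lower of the two numbers so far, at 1880 nM against compound 1 `CN1CCN(c2ccc(Nc3ncc(Cl)c(NCc4ccc(F)cc4)n3)nc2)CC1` at 19300 nM on the same read-out.

Compound 3 `CC(C)c1ccccc1Nc1nc(Nc2ccc(N3CCN(C)CC3)cn2)ncc1Cl` differs from compound 2 in one place: 2-isopropylphenyl in place of 4-isopropylphenyl on a nitrogen on an aromatic ring gives 2-isopropylphenyl in place of 4-isopropylphenyl on a nitrogen on an aromatic ring.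

Going by the values given here, the only measured step at this place is a 10-fold lower number from compound 1 to compound 2 (1.01 log units; beyond the scatter) and it is large. It exchanges 4-fluorobenzyl for 4-isopropylphenyl, so it shows that this place can carry a wide change in number. Among the compounds with values here, no measured pair tests a shift of the isopropyl group, so size and direction remain weakly supported. A modest rise is the working expectation, with a wide range.

The estimate is a 1.9-fold higher number from compound 2 to compound 3 (0.27 log units; within the scatter) as an expected step in this assay for now. For compound 3 the expected value is 3500 nM with an estimated range of 1200 nM to 10000 nM on this read-out.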

Compound 3, concentration for 50% growth inhibition: 4360 nM
Estimate against measurement, compound 3: 1.2-fold (0.10 log units) below; the range from low to high includes it.
By their numbers in this assay, from the lowest: compound 2; then compound 3; then compound 1.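

In this assay, moving the isopropyl group gives a 2.3-fold higher number from compound 2 to compound 3 (0.37 log units; beyond the scatter) and this shows that the number at this place depends on where the isopropyl group sits on the phenyl ring, not only on which group is attached. The 2-isopropylphenyl group still gives a 4.4-fold lower number from compound 1 to compound 3 (0.65 log units; beyond the scatter) and so keeps part of the drop seen on replacing 4-fluorobenzyl with 4-isopropylphenyl, which leaves both isopropylphenyl compounds with lower numbers than compound 1. Nothing measured here explains the difference between the two isopropylphenyl groups.

Open, going by these compounds, is whether a smaller or different group on the phenyl ring, such as a methyl, a methoxy or a carboxylic acid, would give a number near that of compound 2. Also open, on these data alone, is whether either placement holds up with a different group elsewhere on the shared core.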